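Swapping the amide for an oxadiazole ring

The source may report more compounds than this note shows. Statements on the series, on what has been measured and on what is new or still open speak of the compounds shown alone.

Compound 1 `Cc1ccc(-c2nc3cccnc3n2C2CCCCC2)cc1`: 7000 nM
Compound 2 `CCNC(=O)c1ccc(-c2nc3cccnc3n2C2CCCC2)cc1`: 320 nM

Of the compounds shown here, two have been measured in a functional assay on MDA-MB-231 cells (Homo sapiens) for cytotoxicity, read by MTT assay, with a stated time of 24 h; a higher number here means a weaker inhibitor, a lower number a stronger inhibitor. Compound 1 gives 7000 nM, while compound 2 gives 320 nM, the lowest of the two numbers; the gap between them is beyond the scatter. Compound 3 `c1cnc2c(c1)nc(-c1ccc(-c3nnco3)cc1)n2C1CCCC1` has not yet been measured. It differs from compound 2 in one place: 1,3,4-oxadiazol-2-yl in place of ethylcarbamoyl on an aromatic carbon. Going by the values given here, no measured pair shows this change, so its effect can only be guessed. A ring of three heteroatoms replaces an open chain carrying a donor, and the estimate for compound 3 is therefore a modest step in this assay, expected to be a 1.9-fold higher number from compound 2 to compound 3 (0.27 log units; within the scatter), toward a weaker inhibitor. Compound 3 is estimated at 600 nM, with a range from 150 nM to 3000 nM.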

Compound 3, half-maximal inhibitory concentration: 87 nM
The estimate for compound 3 lay 6.9-fold (0.84 log units) above the measured number; measured number outside the range, below it.
By their numbers in this assay, from the lowest: compound 3; then compound 2; then compound 1.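

Replacing ethylcarbamoyl with 1,3,4-oxadiazol-2-yl on this aromatic carbon, para to a large group, gives a 3.7-fold lower number from compound 2 to compound 3 (0.57 log units; beyond the scatter) in this assay and removes the only hydrogen-bond donor of the group at this position. A low number here therefore does not depend on that donor or on an open chain, since a five-membered aromatic ring with the same count of heavy atoms does better. No available measurement explains why the ring gives the lower number.

The compounds shown cannot separate the loss of the amide hydrogen from the gain of the ring, and a tertiary amide or a simple phenyl ring at this position would bear on that. Going by these compounds, it also remains open how a carboxylic acid, an amine, a longer chain or a 1,2,4-oxadiazole would fare here.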